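Aryl variation on the ring nitrogen: compound 3 to compound 4

A few compounds are considered here, and "the series" means these few. Any claim that something is new, unique, unknown or untested is made for them only; others in the source may bear on it.

Three analogues of a shared core have been measured in a functional assay on ECa-109 cells (Homo sapiens) for inhibition, read by MTT assay, with a stated time of 72 h; a higher number here means a weaker inhibitor, a lower number a stronger inhibitor. Compound 1 `CC(C)c1ccc(-c2nc(SCc3cn(CC(=O)NC(=O)Nc4ccccn4)nn3)nc(Nc3cccc(Cl)c3)c2C#N)cc1` gives 13300 nM. Compound 2 `Cc1ccc(Nc2nc(SCc3cn(CC(=O)NC(=O)Nc4ccccn4)nn3)nc(-c3ccc(C(C)C)cc3)c2C#N)cc1` gives 6700 nM. Compound 3 `CC(C)c1ccc(-c2nc(SCc3cn(CC(=O)NC(=O)Nc4ccccn4)nn3)nc(Nc3ccccc3O)c2C#N)cc1` gives 7380 nM, the second highest of the three numbers, nearest to compound 2 and furthest from compound 1; all three values sit within the scatter of one another.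

The measured steps all concern the aryl group on a nitrogen on an aromatic ring: a 2.0-fold lower number from compound 1 to compound 2 (0.30 log units; within the scatter), a 1.8-fold lower number from compound 1 to compound 3 (0.26 log units; within the scatter) and a 1.1-fold higher number from compound 2 to compound 3 (0.04 log units; within the scatter). None of them rises above the scatter, so the three aryl groups tried so far are indistinguishable on these numbers.

Compound 4 `CC(C)c1ccc(Nc2nc(SCc3cn(CC(=O)NC(=O)Nc4ccccn4)nn3)nc(-c3ccc(C(C)C)cc3)c2C#N)cc1` continues the same exchange: 4-isopropylphenyl in place of 2-hydroxyphenyl on a nitrogen on an aromatic ring. Of the measured compounds, compound 2 carries the aryl group most like the incoming one, and its value of 6700 nM lies within the scatter of compound 3. Compound 4 is therefore expected to show no step beyond the scatter in this assay, with a 1.1-fold lower number from compound 3 to compound 4 (0.06 log units; within the scatter) as the estimated shift. The estimate for compound 4 is 6500 nM, with a range from 2500 nM to 17000 nM.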

Compound 4, half-maximal inhibitory concentration: 2490 nM
Beside the measured number, compound 4's estimate is 2.6-fold (0.42 log units) above it; measured number outside the range, below it.
By their numbers in this assay, from the lowest: compound 4; then compounds 2, 3 and 1 (each within the scatter of the next).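

In this assay, within the data shown here, the aryl group on a nitrogen on an aromatic ring now gives a difference beyond the scatter for the first time, with a 3.0-fold lower number from compound 3 to compound 4 (0.47 log units; beyond the scatter) and a 5.3-fold lower number from compound 1 to compound 4 (0.73 log units; beyond the scatter) on exchange for 4-isopropylphenyl, so the numbers at this position are no longer indistinguishable. The closest pair is the most informative: isopropyl in place of methyl on an aromatic carbon gives a 2.7-fold lower number from compound 2 to compound 4 (0.43 log units; beyond the scatter) even though the methyl-bearing aryl group had stood within the scatter of the other two, so a change confined to that one alkyl group is enough to separate compound 4 as the strongest inhibitor of the four. No measurement is available that would explain this step.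

Going by these compounds, it remains open whether the number keeps falling with a longer or more branched group at the same place on the aryl ring, such as tert-butyl or n-butyl, or whether it peaks at isopropyl. An amine or a carboxylic acid on that ring would show whether alkyl groups alone give this kind of step, and the 4-isopropylphenyl group held constant on the shared core is also untested by these four compounds.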